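Swapping hydroxy for amino on a weak cytotoxic quinazoline

The source may report more compounds than this note shows. Statements on the series, on what has been measured and on what is new or still open speak of the compounds shown alone.

Compound 2 has the structure `Oc1ccccc1Nc1nc(-c2cccc(F)c2)nc2ccc(F)cc12`. Among the measured compounds shown here, in a functional assay on U-937 cells (Homo sapiens) for cytotoxicity, read by MTT assay, with a stated time of 48 h (a lower number here means a stronger inhibitor, a higher number a weaker inhibitor), compound 2 gives 46300 nM, the only number among the values shown, and a weak one. Compound 1, with structure `Fc1cccc(-c2nc(Nc3ccccc3F)c3cc(F)ccc3n2)c1`, stands beside it. In this assay compound 1 gives > 50000 nM, which is a limit of the assay rather than a number, as noted in the limit of > 50000 nM in this assay, at which 1 of the 2 values shown sits. For the measured compounds named here, the one measured step, an at least 1.0-fold lower number from compound 1 to compound 2 (0.03 log units; that floor lies within the scatter), lies within the scatter.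

Compound 3, structure `Nc1ccccc1Nc1nc(-c2cccc(F)c2)nc2ccc(F)cc12`, has not been measured. It differs from compound 2 by amino in place of hydroxy on an aromatic carbon. Going by the values given here, the only measured step is a change at this same aromatic carbon, and it stayed within the scatter, so no change beyond the scatter is expected in this assay. The step of a 1.0-fold lower number from compound 2 to compound 3 (0.01 log units; within the scatter) is therefore expected to be small. Compound 3 is estimated at 45000 nM, in a range from 15000 nM to 150000 nM.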

Compound 3, half-maximal inhibitory concentration: 47300 nM
The estimate for compound 3 lay 1.1-fold (0.02 log units) below the measured number; measured number inside the range.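

At this aromatic carbon, ortho to a large group, amino in place of hydroxy gives a 1.0-fold higher number from compound 2 to compound 3 (0.01 log units; within the scatter) in this assay, so these two groups cannot be told apart here. Amino in place of fluoro gives an at least 1.0-fold lower number from compound 1 to compound 3 (0.02 log units; that floor lies within the scatter), which is only a floor and adds a second comparison at the same carbon. Compound 1 stands at a limit of the assay and not at a number, so the true distance from fluoro to amino stays unknown: the limit of > 50000 nM in this assay, at which 1 of the 3 values shown sits.

From the compounds shown here alone, whether a methoxy group, a carboxylic acid or a longer chain at this carbon would move the number beyond the scatter remains open. So does whether amino in place of hydroxy would stay this small on a core that gives a much lower number.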